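Flipping the Double Bond of Compound 2

The compounds below may be only part of what the source reports. "The series", "measured", "known", "first", "only" and "open" are said of these compounds alone.

Compound 1 `CCNC(=O)Nc1ccc(/C=C\c2cccc(Cl)c2)cc1`: 31000 nM
Compound 2 `CCNC(=O)Nc1ccc(/C=C\c2cc(OC)c(OC)c(OC)c2)cc1`: 29000 nM

In a functional assay on HT-1080 cells (Homo sapiens) for inhibition, read by sulforhodamine B assay, with a stated time of 48 h (a higher number here means a weaker inhibitor, a lower number a stronger inhibitor), compound 2 gives 29000 nM and lies within the scatter of compound 1 at 31000 nM (the two cannot be told apart). Compound 3 `CCNC(=O)Nc1ccc(/C=C/c2cc(OC)c(OC)c(OC)c2)cc1` keeps every atom and bond of compound 2, and only the geometry differs: the two compounds have the same atoms and bonds and differ only in configuration as drawn: 1 of 1 stereo elements differ; a double bond is drawn Z in compound 2 and E in compound 3. For the measured compounds named here, no measured pair here shows what such a change does, so any forecast is uncertain. A small loss of inhibition is the modest expectation, with the estimated size being a 1.4-fold higher number from compound 2 to compound 3 (0.14 log units; within the scatter) and possibly no change beyond the scatter. In this assay compound 3 is expected at 40000 nM (range 15000 nM to 100000 nM).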

Compound 3, half-maximal inhibitory concentration: 16000 nM
Estimate against measurement, compound 3: 2.5-fold (0.40 log units) above; the range from low to high includes it.
By their numbers in this assay, from the lowest: compounds 3, 2 and 1 (each within the scatter of the next).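

In this assay, for the compounds shown here, the flip of the double bond from Z to E stays inside the scatter (a 1.8-fold lower number from compound 2 to compound 3 (0.26 log units; within the scatter)), so this is the first sign that the drawn geometry at this position may matter little. With one pair, that reading rests on a single case, although the comparison itself is clean: the fact that compounds 2 and 3 differ only in the configuration as drawn.

Still open, going by these compounds, is whether the same flip would behave alike in compound 1, with its chlorine. Also open, on these data alone, is what an amine or a carboxylic acid in place of that chlorine would do to these numbers.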